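Shrinking the Ring on the Thiocarbonyl Carbon

The source may report more compounds than this note shows. Statements on the series, on what has been measured and on what is new or still open speak of the compounds shown alone.

Two measured compounds share one core and differ only in the ring attached to the thiocarbonyl carbon. Compound 1 `Cc1ccnc(/C(N)=N/NC(=S)N2CCSCC2)c1` carries a thiomorpholin-4-yl ring there, and in a functional assay on A-431 cells (Homo sapiens) for cytotoxicity, read by MTT assay, with a stated time of 72 h, tested at 30 uM (on this read-out lower numbers stand for less inhibition of growth and higher numbers for more inhibition of growth at the one concentration tested), compound 1 gives 75.3%. Compound 2 `Cc1ccnc(/C(N)=N/NC(=S)N2CCCCC2)c1` carries a piperidin-1-yl ring in its place, and in this assay compound 2 gives 62.8%. For the measured compounds named here, the step of a number 12.5 percentage points lower from compound 1 to compound 2 (beyond the scatter) lies beyond the scatter, so of the two numbers available compound 2 stands lowest, with compound 1 as its only neighbour.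

Compound 3 `Cc1ccnc(/C(N)=N/NC(=S)N2CCCC2)c1` is not yet measured. Its change from compound 2 is pyrrolidin-1-yl in place of piperidin-1-yl on a thiocarbonyl carbon. Going by the values given here, the only measured step at this position, a number 12.5 percentage points lower from compound 1 to compound 2 (beyond the scatter), exchanged one six-membered ring for another and was modest; no measured step changes the size of the ring, so nothing here points in a direction for moving to a five-membered ring. The step of a number 2.8 percentage points lower from compound 2 to compound 3 (within the scatter) is therefore expected to stay small, within or close to the scatter. Compound 3 is estimated at 60%, within a range from 40% to 80%.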

Compound 3, percent growth inhibition at one concentration: 84.2%
The estimate for compound 3 lay 24.2 percentage points below the measured number, outside the stated range (above it).
By their numbers in this assay, from the lowest: compound 2; then compounds 1 and 3 (each within the scatter of the next).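

For the compounds shown here, the ring size on the thiocarbonyl carbon clearly matters in this assay: a five-membered pyrrolidin-1-yl ring in place of the six-membered piperidin-1-yl ring gives a number 21.4 percentage points higher from compound 2 to compound 3 (beyond the scatter), the first measured step at this position that changes the size of the ring. Ring size alone does not sort the three compounds, however, since the step of a number 8.9 percentage points higher from compound 1 to compound 3 (within the scatter) leaves the six-membered thiomorpholin-4-yl ring of compound 1 and the five-membered ring of compound 3 indistinguishable, and compound 1 goes against any simple rule that smaller rings give more inhibition of growth; of the three, only compound 2, with piperidin-1-yl, stands apart from the other two by more than the scatter. Nothing available explains why these rings rank as they do.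

Still open, as far as these compounds go, is how a morpholin-4-yl ring, with oxygen in place of the sulfur of thiomorpholin-4-yl, or a seven-membered azepan-1-yl ring would behave at this position. An open-chain dimethylamino group would show whether a ring is needed on the thiocarbonyl carbon at all.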